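This account rests on a few compounds, and the source may have more. Where it says the series, first, only, none or still open, it means among the compounds named here.

Measured compounds:
- compound 1, `CCc1ccccc1NC(=O)N[C@@H](C)c1ccccc1`: 95%
- compound 2, `CC(C)c1ccccc1NC(=O)N[C@@H](C)c1ccccc1`: 93%
- compound 3, `C[C@H](NC(=O)Nc1ccccc1F)c1ccccc1`: 65%

In an ADME assay on the whole organism with Oryza sativa as the target, tested at 10 uM (on this read-out lower numbers stand for a stronger effect and higher numbers for a weaker effect at the one concentration tested), compound 3 shows the lowest number of the three, and the two steps leading to it, a number 30 percentage points lower from compound 1 to compound 3 (beyond the scatter) and a number 28 percentage points lower from compound 2 to compound 3 (beyond the scatter), both lie beyond the scatter, so compound 3 has the strongest effect seen so far. Compound 4, `C[C@H](NC(=O)Nc1ccccc1Br)c1ccccc1`, has not been measured. It differs from compound 3 in one place: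

bromo in place of fluoro on an aromatic carbon

Going by the values given here, no measured pair swaps one halogen for another, so the only steps that bear on this change are those that arrived at the fluoro group: a number 30 percentage points lower from compound 1 to compound 3 (beyond the scatter) and a number 28 percentage points lower from compound 2 to compound 3 (beyond the scatter). Both show that putting fluoro in place of an alkyl group on that aromatic carbon lowered the number by a modest amount. Replacing fluoro by bromo, a different one-atom group, is expected to give back part of that drop, so the estimated step of a number 13 percentage points higher from compound 3 to compound 4 (beyond the scatter) points upward. Compound 4 is therefore estimated at 78%, within 58% to 95%.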

Compound 4, a percentage reported as activity, at one concentration (the size of the read-out at that concentration, not a potency): 102%
Compound 4: middle estimate off by 24 percentage points, on the low side; measured number above the stated range.
By their numbers in this assay, from the lowest: compound 3; then compounds 2, 1 and 4 (each within the scatter of the next).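

In this assay the low number turns out to belong to fluoro itself, not to the presence of any small single atom on this aromatic carbon: swapping one halogen atom for another gives a number 37 percentage points higher from compound 3 to compound 4 (beyond the scatter) and that step is large. Bromo cannot be told apart from the alkyl groups here, since a number 9 percentage points higher from compound 2 to compound 4 (within the scatter) and a number 7 percentage points higher from compound 1 to compound 4 (within the scatter) both stay within the scatter, which leaves compound 3 alone with the stronger effect among these four compounds. Nothing available explains why fluoro and bromo part so sharply.

Still open, going by these compounds, is whether chloro or a plain hydrogen on this aromatic carbon would side with fluoro or with the bromo and alkyl group. The compounds shown also say nothing about how a methoxy group or an amine would fare there.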